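A few compounds are considered here, and "the series" means these few. Any claim that something is new, unique, unknown or untested is made for them only; others in the source may bear on it.

Three compounds sharing one core have been examined in an ADME assay on THP-1 cells (Homo sapiens) for cytotoxicity; a higher number here means that more compound is tolerated, a lower number that less compound is tolerated. Compound 1 `Fc1cccc(Nc2c(-c3ccccn3)nc3ccccn23)c1` gives only a limit there, > 50000 nM. Compound 2 `COCc1ccn2c(Nc3cccc(F)c3)c(-c3ccccn3)nc2c1` gives 7370 nM, and compound 3 `CN(C)Cc1ccn2c(Nc3cccc(F)c3)c(-c3ccccn3)nc2c1` gives 33300 nM, the highest of the two numbers; the step of a 4.5-fold higher number from compound 2 to compound 3 (0.65 log units; beyond the scatter) lies beyond the scatter. The steps from compound 1 were an at least 6.7-fold lower number from compound 1 to compound 2 (0.83 log units; beyond the scatter) and an at least 1.5-fold lower number from compound 1 to compound 3 (0.17 log units; that floor lies within the scatter), so a substituent on that aromatic carbon can lower the number markedly (compound 2) or only slightly (compound 3). Compound 4 `Oc1ccn2c(Nc3cccc(F)c3)c(-c3ccccn3)nc2c1` differs from compound 3 by hydroxy in place of (dimethylamino)methyl on an aromatic carbon. Among the measured compounds shown here, no measured step involves a hydroxy, so the comparison is indirect. For compound 4 a small change is expected, a 1.3-fold lower number from compound 3 to compound 4 (0.12 log units; within the scatter). The estimate for compound 4 is 25000 nM, with a range from 8000 nM to 80000 nM.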

Compound 4, half-maximal cytotoxic concentration: 43300 nM
Estimate against measurement, compound 4: 1.7-fold (0.24 log units) below, and the stated range covers the measured number.
By their numbers in this assay, from the lowest: compound 2; then compounds 3 and 4 (each within the scatter of the next). At a limit, above all of these: compound 1.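

Swapping (dimethylamino)methyl for hydroxy on this aromatic carbon, opposite the ring nitrogen, does not separate the two compounds in this assay: a 1.3-fold higher number from compound 3 to compound 4 (0.11 log units; within the scatter). Compound 2, with methoxymethyl, stays apart from the hydroxy compound, with a 5.9-fold higher number from compound 2 to compound 4 (0.77 log units; beyond the scatter). The step of an at least 1.1-fold lower number from compound 1 to compound 4 (0.06 log units; that floor lies within the scatter) rests on a limit for compound 1 and gives only a floor, so no difference between hydroxy and hydrogen can be read from it. On these data alone, whether a carboxylic acid, an amine set directly on this carbon or a longer chain would fall with compound 2 or with compounds 3 and 4 remains open.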